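Compound 1 to compound 3: one aryl group exchanged

The source may report more compounds than this note shows. Statements on the series, on what has been measured and on what is new or still open speak of the compounds shown alone.

Measured so far:
compound 1 `CCN(CC)c1ccc(N2C(=O)CSC2c2cccc(C(=O)NCCCCc3ccccc3)c2)cc1`: > 1000 nM (a limit)
compound 2 `C#Cc1cc(C(=O)NCCCCc2ccccc2)cc(C2SCC(=O)N2c2ccccc2OC)c1`: 40.8 nM

Compound 1 stands at > 1000 nM in a functional assay on HOS-TE85 cells (Homo sapiens) for inhibition, read by CCK-8 assay, with a stated time of 72 h (on this read-out lower numbers stand for stronger inhibition and higher numbers for weaker inhibition), and this is a limit of the assay, not a number. Compound 2 reads 40.8 nM in this assay, but it differs from compound 1 in more than one place, so no single change can be read from that pair.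

The next compound is compound 3 `Cc1cccc(N2C(=O)CSC2c2cccc(C(=O)NCCCCc3ccccc3)c2)c1`, which keeps the core of compound 1 and changes one group: 3-methylphenyl in place of 4-(diethylamino)phenyl on an amide-type nitrogen in a ring. In words, 3-methylphenyl sits in place of 4-(diethylamino)phenyl on an amide-type nitrogen in a ring.

For the measured compounds named here, no measured single-place step exists to size this change, and the starting point is only a limit. A moderate move toward stronger inhibition in this assay is still expected, since compound 2 at 40.8 nM shows that the series can read low. The expected step is an at least 3.3-fold lower number from compound 1 to compound 3 (0.52 log units; beyond the scatter). A reading that returns only a limit remains possible. For compound 3 the estimated value is 300 nM, with an expected range of 60 nM to 1500 nM.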

Compound 3, half-maximal inhibitory concentration: 93.2 nM
Beside the measured number, compound 3's estimate is 3.2-fold (0.51 log units) above it, and the stated range covers the measured number.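

In this assay, for the compounds shown here, 3-methylphenyl in place of 4-(diethylamino)phenyl on the amide-type nitrogen in a ring gives an at least 10-fold lower number from compound 1 to compound 3 (1.03 log units; beyond the scatter), the first single-place step. With the rest of compound 1 held fixed, the aryl group on this nitrogen alone is enough to turn a limit into a measured number. The reading for compound 1 is a limit and not a number, so the step fixes only a lower bound on its size: the limit of > 1000 nM in this assay, at which 1 of the 3 values shown sits.

The exchange swaps the substituent and its ring place together, so the pair cannot say which of the two carries the step; 4-methylphenyl, 3-(diethylamino)phenyl or plain phenyl on the same nitrogen would separate them. Going by these compounds, how 3-methylphenyl ranks against the 2-methoxyphenyl of compound 2 also stays open, as compound 2 differs from compound 3 in more than one place, and a 3-methoxyphenyl or 2-methylphenyl on the core of compound 3 would be the closer comparison.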